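Chalcone analogues: trifluoromethyl against chloro in HeLa growth inhibition

A few compounds are considered here, and "the series" means these few. Any claim that something is new, unique, unknown or untested is made for them only; others in the source may bear on it.

Compound 1 `COc1cc(O)c(CC=C(C)C)c(O)c1C(=O)/C=C/c1ccc(Cl)cc1`, compound 2 `COc1cc(O)c(CC=C(C)C)c(O)c1C(=O)/C=C/c1ccc(C(F)(F)F)cc1` and compound 3 `COc1cc(OC)c(C(=O)/C=C/c2ccc(C(F)(F)F)cc2)c(OC)c1` were examined in a functional assay on HeLa cells (Homo sapiens) for inhibition, read by MTT assay, with a stated time of 72 h; on this read-out lower numbers stand for stronger inhibition and higher numbers for weaker inhibition. Compound 1 gives 16500 nM, compound 2 gives 6800 nM and compound 3 gives 5100 nM. Compound 2 and compound 3 share the same side-chain group, but the difference between their two cores is not broken down here. One change appears twice among these compounds: chloro in place of trifluoromethyl on an aromatic carbon It produced a 2.4-fold higher number from compound 2 to compound 1 (0.38 log units; beyond the scatter). Compound 4 `COc1cc(OC)c(C(=O)/C=C/c2ccc(Cl)cc2)c(OC)c1` has not yet been measured; it differs from compound 3 by the same change, (chloro in place of trifluoromethyl on an aromatic carbon), at the same place. Since this change gave a 2.4-fold higher number from compound 2 to compound 1 (0.38 log units; beyond the scatter), a step of similar size is expected on the core of compound 3, so compound 4 is estimated to show a 2.4-fold higher number from compound 3 to compound 4 (0.37 log units; beyond the scatter). In this assay compound 4 is expected to give 12000 nM, most likely between 5000 nM and 30000 nM.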

Compound 4, half-maximal inhibitory concentration: 3900 nM
For compound 4 the middle estimate is 3.1-fold (0.49 log units) above the measured one; measured number below the stated range.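

Replacing trifluoromethyl with chloro gave a 1.3-fold lower number from compound 3 to compound 4 (0.12 log units; within the scatter) in this assay, so on this core the change produced no step beyond the scatter. Set beside the step on the core of compound 2, this shows that the size of the change did not carry over from one core to the other: the same change on two cores in this assay, a 2.4-fold higher number (0.38 log units; beyond the scatter) from compound 2 to compound 1 and a 1.3-fold lower number (0.12 log units; within the scatter) from compound 3 to compound 4, 3.2-fold (0.50 log units) apart, beyond the scatter of two such steps The comparison rests on a single pair for each core, and it does not show which feature of the cores goes with the difference or how the change would behave on a third core.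

The compounds shown leave open how other groups on the same aromatic carbon, such as a nitrile or an amine, would behave on these two cores. They also leave open whether such groups would differ between the cores as chloro and trifluoromethyl do.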